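The compounds below may be only part of what the source reports. "The series", "measured", "known", "first", "only" and "open" are said of these compounds alone.

Measured so far:
compound 1 `ClCc1ccc(Cn2cnc3c(Cl)ncnc32)cc1` — 2390 nM
compound 2 `ClCc1ccccc1Cn1cnc2c(Cl)nc(Cl)nc21` — 3090 nM

For the measured compounds named here, only two compounds have numbers in a functional assay on CAKI-1 cells (Homo sapiens) for cytotoxicity, read by sulforhodamine B assay, with a stated time of 48 h; a higher number here means that more compound is tolerated, a lower number that less compound is tolerated. Compound 2 gives 3090 nM and stands with the higher of the two numbers; the nearest is compound 1, which gives 2390 nM, and the gap between the two lies within the scatter, so the pair is read as level.

Compound 3 `ClCc1ccccc1Cn1cnc2c(Cl)ncnc21` is still to be measured. It differs from compound 2 in a single place: hydrogen in place of chloro on an aromatic carbon. Going by the values given here, no step between two measured compounds of this kind exists, so the size of the change is not known from the series itself. The two numbers that exist lie close together and give no sign that the core substitution moves the read-out much. The expectation for compound 3 in this assay is therefore a step of no size beyond the scatter, a 1.1-fold lower number from compound 2 to compound 3 (0.06 log units; within the scatter), with either direction left open.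

Compound 3 is estimated at 2700 nM, with a range from 1300 nM to 5500 nM.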

Compound 3, concentration lethal to 50% of the cells: 9330 nM
Beside the measured number, compound 3's estimate is 3.5-fold (0.54 log units) below it; measured number outside the range, above it.
By their numbers in this assay, from the lowest: compounds 1 and 2 (each within the scatter of the next); then compound 3.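

In this assay, for the compounds shown here, the aromatic carbon between two ring nitrogen atoms proves not to be a silent place: hydrogen in place of chloro there gives a 3.0-fold higher number from compound 2 to compound 3 (0.48 log units; beyond the scatter), the first step that reads beyond the scatter. The closeness of the first two numbers therefore said nothing about this position, and the read-out does respond to a single change of one heavy atom on the shared core, with more compound tolerated once the chloro group has gone. No measurement on these compounds bears on why the number moves at this carbon.

The compounds shown leave open whether this is a simple matter of chloro against hydrogen or whether other groups on the same carbon, such as an amine, a methoxy group or a methyl group, would fall with compound 2, with compound 3 or elsewhere. Going by these compounds alone, it also remains open whether the same replacement gives a step of this size when the chloromethyl group sits elsewhere on the benzene ring, since the series holds only this one pair.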